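A few compounds are considered here, and "the series" means these few. Any claim that something is new, unique, unknown or untested is made for them only; others in the source may bear on it.

Of the compounds shown here, three have been tested in an ADME assay on microsomes from liver (Mus musculus) for metabolic stability, read by LC-MS, with NADPH named in the record, with a stated time of 60 min, tested at 1 uM, in the absence of a further agent; a higher number here means that more of the compound is left, a lower number that less of the compound is left: compound 1 (`COc1ccc(-c2c(C)oc3c(N4CC[C@@H](NC(C)=O)C4)cc(C)nc23)cc1OC`), compound 2 (`CC(=O)N[C@@H]1CCN(c2cc(C)nn3c(-c4ccc5cc[nH]c5c4)c(C)nc23)C1`) and compound 3 (`COc1ccc(-c2c(C)nc3c(N4CC[C@@H](NC(=O)NC(C)C)C4)cc(C)nn23)cc1OC`). Compound 1 gives > 95%, which is a limit of the assay and not a number. Compound 2 gives > 95%, again a limit. Compound 3 gives > 95%, also a limit, so it has no exact number to start from. Compound 4 (`COc1ccc(-c2c(C)nc3c(N4CC[C@@H](NS(=O)(=O)C5CC5)C4)cc(C)nn23)cc1OC`) keeps the core of compound 3 and carries cyclopropylsulfonyl in place of isopropylcarbamoyl on an amine nitrogen. Going by the values given here, no measured pair of compounds shows what such a change does in this assay. Among the compounds with values here, the only guide is the limit of > 95% in this assay, at which 3 of the 3 values shown sit, so no shift beyond the scatter is expected, with any small movement more likely downward. The expected size of the change is a number at least 1 percentage points lower from compound 3 to compound 4 (that floor lies within the scatter), an estimate that a limit on the starting value leaves loose. For compound 4 the estimated value is 94%, with an expected range from 78% to 100%.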

Compound 4, percent of the compound remaining: > 95%
Compound 4: only a limit was reported (the forecaster's own chance of this, stated with the estimate: 60%); at least 1 percentage points between middle value and limit.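

Compound 3 and compound 4 both stand at a reported limit and not at a number, so the step between them cannot be read. The compounds shown leave open how much of each actually remains, and whether any change on the amine nitrogen moves that figure.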